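Sulfonylpiperidine carboxamides: the step from compound 2 to compound 4

The source may hold more compounds than are shown below. What is called first, only, known or untested is meant among the compounds shown, and "the series" means these compounds.

Measured so far in a functional assay on MIA PaCa-2 cells (Homo sapiens) for inhibition, read by MTT assay, with a stated time of 3 days; a higher number here means a weaker inhibitor, a lower number a stronger inhibitor:
Compound 1, `CCOC(=O)[C@@H]1CCCN(S(=N)(=O)c2ccc(S(=O)(=O)N(CC)CC)cc2)C1`: compound 1 gives 4700 nM.
Compound 3, `CCOC(=O)[C@@H]1CCCN(S(=O)(=O)c2ccc(S(=O)(=O)N(CC)CC)cn2)C1`: compound 3 gives 300 nM.
Compound 2, `CCN1CC(NC(=O)[C@@H]2CCCN(S(=O)(=O)c3ccc(S(=O)(=O)N(CC)CC)cc3)C2)C1`: compound 2 gives only a limit, > 10000 nM.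

For the measured compounds named here, compound 2 therefore stands at the limit of > 10000 nM in this assay, at which 1 of the 3 values shown sits, and it is the one compound of the three for which no number is known. Compound 1 and compound 3 each give a number; compound 2 does not, so its place relative to them can be stated only as weaker than either, without a size.

Compound 4, `CCN(CC)S(=O)(=O)c1ccc(S(=O)(=O)N2CCC[C@@H](C(=O)N3CCN(c4nc(C)no4)CC3)C2)cc1`, differs from compound 2 by 4-(3-methyl-1,2,4-oxadiazol-5-yl)piperazin-1-yl in place of (1-ethylazetidin-3-yl)amino on a carbonyl carbon. Going by the values given here, no measured pair isolates this change, so no step in this assay is known for it, and with compound 2 itself a limit the step cannot be anchored at its start. Both compounds keep the same core and the same amide carbonyl; what changes is only the group on the carbonyl carbon. On that basis no step beyond the scatter is expected, although a gain in potency cannot be excluded, and the estimate carries a wide range. Compound 4 is expected to give 8000 nM, with a range of 2000 nM to 30000 nM. The step this implies, an at least 1.2-fold lower number from compound 2 to compound 4 (0.09 log units; that floor lies within the scatter), is an expectation only, and a further limit reading is about as likely as a number.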

Compound 4, half-maximal inhibitory concentration: 200 nM
Compound 4: the middle estimate sits 40-fold (1.60 log units) above what was measured; measured number below the stated range.
By their numbers in this assay, from the lowest: compounds 4 and 3 (each within the scatter of the next); then compound 1. At a limit, above all of these: compound 2.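

For the compounds shown here, the group on the carbonyl carbon proves to be a position of large effect: in this assay, 4-(3-methyl-1,2,4-oxadiazol-5-yl)piperazin-1-yl in place of (1-ethylazetidin-3-yl)amino gives an at least 50-fold lower number from compound 2 to compound 4 (1.69 log units; beyond the scatter), a change in this place that no earlier pair could show. The amide carbonyl alone therefore does not account for the weak reading of compound 2, since compound 4 keeps that carbonyl and gives 200 nM. Compound 2 is a limit and not a number, so this step is a floor and its full size stays unknown: the limit of > 10000 nM in this assay, at which 1 of the 4 values shown sits.

The two rings of the entering group arrive together, so this pair cannot tell whether the piperazine or the 1,2,4-oxadiazole carries the step; a plain 4-acetylpiperazin-1-yl group on the same carbonyl carbon would begin to separate them. From the compounds shown here alone, it also remains open whether the leaving side owes its reading to the azetidine ring, the ethyl on it or the amide hydrogen, which a dimethylamino group in the same place would help to address.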